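Replacing a Dimethylamino Group Ahead of a Half-Life Measurement

The compounds below may be only part of what the source reports. "The series", "measured", "known", "first", "only" and "open" are said of these compounds alone.

Compound 1, `Cc1cc(OCc2ccc(F)cc2F)c(Br)c(=O)n1Cc1ccc(CN(C)C)cc1`: 4.97 h
Compound 2, `Cc1cnc(-n2c(C)cc(OCc3ccc(F)cc3F)c(Br)c2=O)cn1`: 0.39 h

In an in vivo ADME assay on the whole organism (strain Sprague-Dawley) for metabolic stability, with Rattus norvegicus as the target (on this read-out higher numbers stand for a longer-lived compound and lower numbers for a shorter-lived compound), compound 1 gives 4.97 h, the higher of the two numbers; compound 2 gives a far lower value in this assay, a gap beyond the usual scatter. Compound 3, `Cc1cc(OCc2ccc(F)cc2F)c(Br)c(=O)n1Cc1ccc(CNC(=O)CO)cc1`, keeps the core of compound 1 but carries ((hydroxymethyl)carbonyl)amino in place of dimethylamino on a saturated chain carbon bound to an aromatic carbon. Going by the values given here, no measured pair shows this change, so the step in this assay is uncertain; the estimated step from compound 1 to compound 3 is a 2.0-fold lower number from compound 1 to compound 3 (0.30 log units; within the scatter), expected to be modest and perhaps toward a shorter-lived compound. Compound 3 is expected to give 2.5 h, between 0.8 h and 8 h.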

Compound 3, half-life: 4.1 h
Beside the measured number, compound 3's estimate is 1.6-fold (0.21 log units) below it; low and high end bracket the measured number.
By their numbers in this assay, from the lowest: compound 2; then compounds 3 and 1 (each within the scatter of the next).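

In this assay, ((hydroxymethyl)carbonyl)amino in place of dimethylamino on a saturated chain carbon bound to an aromatic carbon gives a 1.2-fold lower number from compound 1 to compound 3 (0.08 log units; within the scatter). The half-life at this place therefore does not rest on keeping dimethylamino, even though the entering group is larger and adds an amide carbonyl. No measurement on hand explains why the two groups read alike.

On these data alone, whether a primary amine, a carboxylic acid or a longer chain at this place would also read alike remains open. One exchange cannot show how far this tolerance extends.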